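Swapping the Aryl Group on a Shared Thiourea Core

The source may hold more compounds than are shown below. What is called first, only, known or untested is meant among the compounds shown, and "the series" means these compounds.

Of the compounds shown here, three that share one core have been measured. Compound 1 `CNC(=O)c1ccc(Oc2cccc(NC(=S)Nc3ccc(C)c(C)c3)c2)nc1` gives 67400 nM in a functional assay on PC-3 cells (Homo sapiens) for antiproliferative activity, read by MTT assay; a higher number here means a weaker inhibitor, a lower number a stronger inhibitor. Compound 2 `CNC(=O)c1ccc(Oc2cccc(NC(=S)Nc3ccc(F)cc3)c2)nc1` gives 32700 nM, and compound 3 `CNC(=O)c1ccc(Oc2cccc(NC(=S)Nc3cccc(C(F)(F)F)c3)c2)nc1` gives 15400 nM. Compound 3 thus carries the lowest number of the three, and the steps of a 2.1-fold lower number from compound 1 to compound 2 (0.31 log units; beyond the scatter), a 4.4-fold lower number from compound 1 to compound 3 (0.64 log units; beyond the scatter) and a 2.1-fold lower number from compound 2 to compound 3 (0.33 log units; beyond the scatter) are all modest yet beyond the scatter. Compound 4 `CNC(=O)c1ccc(Oc2cccc(NC(=S)Nc3ccc(Cl)cc3Cl)c2)nc1` differs from compound 3 by one change: 2,4-dichlorophenyl in place of 3-(trifluoromethyl)phenyl on an amide-type nitrogen. Every measured step likewise exchanged one aryl group on the same nitrogen for another, and each shifted the number only modestly. A shift of similar size is therefore expected here, probably small and in either direction, as the expected step of a 1.3-fold lower number from compound 3 to compound 4 (0.11 log units; within the scatter) shows. Compound 4 is estimated at 12000 nM, with a range from 5000 nM to 30000 nM.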

Compound 4, half-maximal inhibitory concentration: 19300 nM
Compound 4: middle estimate off by 1.6-fold (0.21 log units), on the low side; measured number inside the range.
By their numbers in this assay, from the lowest: compounds 3, 4 and 2 (each within the scatter of the next, the first and the last beyond it); then compound 1.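

The 2,4-dichlorophenyl group gives a number close to those of the other two halogen-bearing aryl groups, with a 1.3-fold higher number from compound 3 to compound 4 (0.10 log units; within the scatter) and a 1.7-fold lower number from compound 2 to compound 4 (0.23 log units; within the scatter). Against the 3,4-dimethylphenyl group, the change gives a 3.5-fold lower number from compound 1 to compound 4 (0.54 log units; beyond the scatter), so all three aryl groups carrying fluorine or chlorine now sit beyond the scatter from compound 1, with no exception among these four compounds. No available evidence explains this ordering.

Still open, on these data alone, is whether this nitrogen needs an aryl group at all. A saturated cyclohexyl ring or a longer alkyl chain there, or a carboxylic acid on the aryl ring, would address that.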